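The source may report more compounds than this note shows. Statements on the series, on what has been measured and on what is new or still open speak of the compounds shown alone.

Measured in a physicochemical assay for lipophilicity, read by HPLC, at pH 7.5; a higher number here means a more lipophilic compound, a lower number a more polar compound:
Compound 1 `CC[C@@H](Nc1c(C#N)c(-c2ccc(-c3ccc(OC)cc3)cc2)nc2cnccc12)C(N)=O`: 2.7
Compound 2 `CC[C@@H](Nc1c(C#N)c(-c2ccc(-c3ccccc3C(F)(F)F)cc2)nc2cnccc12)C(N)=O`: 3.1

Of these two, compound 2 stands higher, at 3.1. Compound 3 `CC[C@@H](Nc1c(C#N)c(-c2ccc(-c3ccccc3C(C)C)cc2)nc2cnccc12)C(N)=O` differs from it in one place, isopropyl in place of trifluoromethyl on an aromatic carbon, ortho to a large group. Going by the values given here, no measured step exchanges these two groups. Among the compounds with values here, the closest guide is the only step available, a number 0.40 log units higher from compound 1 to compound 2 (beyond the scatter), which also changed a substituted phenyl and was modest. A modest upward move in this assay is therefore expected. The expected step is a number 0.30 log units higher from compound 2 to compound 3 (within the scatter). For compound 3 the estimated value is 3.4, within an expected range of 3 to 3.8.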

Compound 3, distribution coefficient: 3.5
Beside the measured number, compound 3's estimate is 0.10 log units below it; low and high end bracket the measured number.
By their numbers in this assay, from the lowest: compound 1; then compound 2; then compound 3.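

The earlier step replaced a whole substituted phenyl, whereas here a single group on an aromatic carbon, ortho to a large group, is exchanged and the number in this assay still moves: isopropyl in place of trifluoromethyl gives a number 0.40 log units higher from compound 2 to compound 3 (beyond the scatter), although isopropyl has 3 heavy atoms against 4 for trifluoromethyl. Taken as a whole, 2-isopropylphenyl in place of 4-methoxyphenyl gives a number 0.80 log units higher from compound 1 to compound 3 (beyond the scatter), the widest step so far. Nothing available accounts for either step.

From the compounds shown here alone, what an amine or a carboxylic acid would give at this place remains open. So does whether a longer chain would take the number past that of isopropyl.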